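The source may report more compounds than this note shows. Statements on the series, on what has been measured and on what is new or still open speak of the compounds shown alone.

In a functional assay on MCF7 cells (Homo sapiens) for inhibition, read by MTT assay, with a stated time of 72 h (a lower number here means a stronger inhibitor, a higher number a weaker inhibitor), two compounds have been measured so far:

- compound 1 `O=C(O)CCCCCCC(=O)Nc1ccc(C2=C(c3ccc(O)cc3)C3CC(S(=O)(=O)Oc4cccc5ccccc45)C2O3)cc1`: 4700 nM
- compound 2 `COc1ccccc1OS(=O)(=O)C1CC2OC1C(c1ccc(NC(=O)CCCCCCC(=O)NO)cc1)=C2c1ccc(O)cc1`: 25800 nM

Compound 2 holds the higher of these two numbers, which makes it the weaker inhibitor of the pair, and the gap to compound 1 at 4700 nM lies beyond the scatter. Compound 3 `O=C(CCCCCCC(=O)Nc1ccc(C2=C(c3ccc(O)cc3)C3CC(S(=O)(=O)Oc4ccccc4)C2O3)cc1)NO` departs from compound 2 in one place: hydrogen in place of methoxy on an aromatic carbon. In words, hydrogen stands in place of methoxy on an aromatic carbon, ortho to a large group, so that 2-methoxyphenoxy becomes phenoxy. Among the compounds with values here, no measured pair isolates this change, so the data do not show its size. A small step towards a lower number in this assay is expected, and it may not exceed the scatter. The expected step is a 1.6-fold lower number from compound 2 to compound 3 (0.21 log units; within the scatter). The estimate for compound 3 is 16000 nM, with an expected range from 6000 nM to 40000 nM.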

Compound 3, half-maximal inhibitory concentration: 30100 nM
The estimate for compound 3 lay 1.9-fold (0.27 log units) below the measured number; measured number inside the range.
By their numbers in this assay, from the lowest: compound 1; then compounds 2 and 3 (each within the scatter of the next).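

Replacing methoxy with hydrogen gives a 1.2-fold higher number from compound 2 to compound 3 (0.07 log units; within the scatter) in this assay. Within the data shown here, this is the first measured pair to isolate the change, and it shows that the methoxy on the aromatic carbon, ortho to a large group, can give way to hydrogen with no difference that this read-out can resolve, so 2-methoxyphenoxy and phenoxy cannot be told apart here. Nothing available explains this result.

On these data alone, whether a different group on this aromatic carbon, such as chlorine, hydroxyl or an amine, would move the number beyond the scatter remains open. This single pair also leaves open whether the same change would read alike with a longer chain on the shared core.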